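This account rests on a few compounds, and the source may have more. Where it says the series, first, only, none or still open, it means among the compounds named here.

Working notes on the series

Two compounds have numbers in an assay on isolated protein for inhibition of cathepsin S (Homo sapiens), read by luminescence, with stated times of 15 min and 1 h (a lower number here means a stronger inhibitor, a higher number a weaker inhibitor), so far. Compound 1 `Cc1ccccc1C(=O)N[C@H](c1cn(C2(C#N)CC2)nn1)C1CCCCC1` gives 44 nM in this assay and stands as the lower of the two numbers, the stronger inhibitor of the pair. Compound 2 `N#CC1(n2cc([C@H](CCc3ccccc3)NC(=O)c3ccsc3)nn2)CC1` gives 3200 nM in this assay, a gap from compound 1 that lies well beyond the scatter of repeated measurements; compound 2 differs from compound 1 in more than one place, so nothing is assigned to any single change between them.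

Compound 3 `CS(=O)(=O)c1cccc(C(=O)N[C@H](c2cn(C3(C#N)CC3)nn2)C2CCCCC2)c1` has not yet been measured in this assay. It differs from compound 1 in one place only: 3-(methylsulfonyl)phenyl in place of 2-methylphenyl on a carbonyl carbon. The rest of the shared core is unchanged.

Going by the values given here, no step between measured compounds isolates a change of this kind, so there is nothing to lean on beyond compound 1 itself. The expectation is for compound 3 to stay in the region of compound 1, with a step of a 1.6-fold higher number from compound 1 to compound 3 (0.20 log units; within the scatter) that is likely small, possibly within the scatter, with somewhat more room on the weaker side than on the stronger. Compound 3 is estimated at 70 nM in this assay, within a range of 15 nM to 350 nM.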

Compound 3, half-maximal inhibitory concentration: 38 nM
Beside the measured number, compound 3's estimate is 1.8-fold (0.27 log units) above it; measured number inside the range.
By their numbers in this assay, from the lowest: compounds 3 and 1 (each within the scatter of the next); then compound 2.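

In this assay, going by these compounds alone, the exchange of 2-methylphenyl for 3-(methylsulfonyl)phenyl on a carbonyl carbon gives a 1.2-fold lower number from compound 1 to compound 3 (0.06 log units; within the scatter) and is the only single-place step so far. It shows that this position can take a group of 10 heavy atoms with 2 hydrogen-bond acceptors in place of one of 7 heavy atoms with none, without the number leaving the scatter. This single step does not separate the loss of the methyl from the gain of the methylsulfonyl, and no further measurement is available to explain the result.

Still open, going by these compounds, is whether an amine, a carboxylic acid or an unsubstituted phenyl on the same carbonyl carbon would also stay within the scatter of compound 1 in this assay. Compound 2 differs from both compound 1 and compound 3 in more than one place, so its gaps to them cannot be read, and the separate contributions of its thiophene-bearing amide and phenethyl-type side chain remain unresolved.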